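The source may hold more compounds than are shown below. What is called first, only, known or untested is meant among the compounds shown, and "the series" means these compounds.

Compound 1 `CCc1nc(-c2cc(C)c(OCCC(C)CCN3CCN(c4ccnc(N)c4)C3=O)c(C)c2)no1`: 15700 nM
Compound 2 `CC(=O)Nc1cc(N2CCN(CCCCCOc3ccc(-c4noc(C)n4)cc3)C2=O)ccn1`: > 100000 nM
Compound 3 `CCONC(=O)c1ccc(OCCC(C)CCN2CCN(c3ccnc(N)c3)C2=O)cc1`: > 100000 nM

In an ADME assay on RD cells (Homo sapiens) for cytotoxicity, read by MTT assay, with a stated time of 24 h (a lower number here means that less compound is tolerated, a higher number that more compound is tolerated), compound 1 gives 15700 nM, the only result of the three that is a number. For compound 2 the assay reports only a limit, > 100000 nM. For compound 3 it likewise reports only a limit, > 100000 nM. Compound 1 therefore stands apart from the limit of > 100000 nM in this assay, at which 2 of the 3 values shown sit.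

Compound 4 `CCCc1nc(-c2cc(C)c(OCCC(C)CCN3CCN(c4ccnc(N)c4)C3=O)c(C)c2)no1` differs from compound 1 by methyl in place of hydrogen on a saturated chain carbon, two bonds along the chain from an aromatic carbon. Going by the values given here, no pair of measured compounds offers a comparison of this size, so the change is expected to bring no step beyond the scatter in this assay. Compound 4 is expected to give 13000 nM, with a range from 5000 nM to 40000 nM. That estimate means an expected step of a 1.2-fold lower number from compound 1 to compound 4 (0.08 log units; within the scatter).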

Compound 4, half-maximal cytotoxic concentration: 14100 nM
Compound 4: middle estimate off by 1.1-fold (0.04 log units), on the low side; low and high end bracket the measured number.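

Going from 5-ethyl-1,2,4-oxadiazol-3-yl to 5-propyl-1,2,4-oxadiazol-3-yl brings a 1.1-fold lower number from compound 1 to compound 4 (0.05 log units; within the scatter) in this assay. Going by these compounds alone, this single added methyl on a saturated chain carbon therefore leaves the result within the scatter, a comparison the earlier compounds could not offer. Compound 4, like compound 1, gives a number rather than a limit of the assay: the limit of > 100000 nM in this assay, at which 2 of the 4 values shown sit.

The compounds shown leave open whether a longer chain, a carboxylic acid or an amine at this end of the 1,2,4-oxadiazol-3-yl group would move the number beyond the scatter.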